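The source may hold more compounds than are shown below. What is called first, only, known or untested is meant among the compounds shown, and "the series" means these compounds.

Compound 1 `CN(C(=O)NC(=O)c1cccc(C(F)(F)F)c1)c1nc(C(F)(F)F)c(C(=O)N/N=C/c2ccc(C(F)(F)F)cc2)s1`, compound 2 `CN(C(=O)NC(=O)c1cccc(C(F)(F)F)c1)c1nc(C(F)(F)F)c(C(=O)N/N=C/c2ccccc2C(F)(F)F)s1` and compound 3 `CN(C(=O)NC(=O)c1ccc(F)c(F)c1)c1nc(C(F)(F)F)c(C(=O)N/N=C/c2cc(C(F)(F)F)cc(C(F)(F)F)c2)s1` share one core and differ in the aryl groups at the two ends. In a functional assay on A549 cells (Homo sapiens) for inhibition, read by MTT assay, with a stated time of 72 h (on this read-out lower numbers stand for stronger inhibition and higher numbers for weaker inhibition), compound 1 gives 6.2 ug/mL, compound 2 gives 12.1 ug/mL and compound 3 gives 5.47 ug/mL. Going by the values given here, the only single-point step among them, a 2.0-fold higher number from compound 1 to compound 2 (0.29 log units; within the scatter), lies within the scatter, so compound 1 and compound 2 cannot be ordered. Compound 2 carries the highest number of the three; its gap to compound 1 is within the scatter, while its gap to compound 3 lies beyond it. Compound 4 `CN(C(=O)NC(=O)c1c(Cl)cccc1Cl)c1nc(C(F)(F)F)c(C(=O)N/N=C/c2ccccc2C(F)(F)F)s1` is obtained from compound 2 by the change (2,6-dichlorophenyl in place of 3-(trifluoromethyl)phenyl on a carbonyl carbon). Among the compounds with values here, no measured step touches that carbonyl aryl group alone: compound 3 differs from compound 2 in two places at once, so its value cannot be assigned to either change. Without a bearing step, the expected step of a 1.1-fold lower number from compound 2 to compound 4 (0.04 log units; within the scatter) is none beyond the scatter. Compound 4 is therefore estimated at 11 ug/mL, within 4.5 ug/mL to 27 ug/mL.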

Compound 4, half-maximal inhibitory concentration: 12 ug/mL
For compound 4 the middle estimate is 1.1-fold (0.04 log units) below the measured one; measured number inside the range.
By their numbers in this assay, from the lowest: compounds 3, 1, 4 and 2 (each within the scatter of the next, the first and the last beyond it).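

In this assay, 2,6-dichlorophenyl in place of 3-(trifluoromethyl)phenyl on a carbonyl carbon whose other neighbour is an amide-type nitrogen gives a 1.0-fold lower number from compound 2 to compound 4 (0.00 log units; within the scatter), which lies within the scatter. This is the first step shown that touches the carbonyl aryl group alone, and with 2-(trifluoromethyl)phenyl at the other end, the two groups cannot be told apart at this position. Nothing measured here bears on why the two groups read alike.

Whether the two groups also read alike with 4-(trifluoromethyl)phenyl at the other end stays open, as the compounds shown offer this exchange only with 2-(trifluoromethyl)phenyl there. Also open, going by these compounds, is what a phenyl ring carrying an amine or a carboxylic acid, or a saturated cyclohexyl ring, would give on this carbonyl carbon.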